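This account rests on a few compounds, and the source may have more. Where it says the series, first, only, none or still open, it means among the compounds named here.

Of the compounds shown here, three built on one shared core have been measured in a functional assay on ACHN cells (Homo sapiens) for inhibition, read by sulforhodamine B assay, with a stated time of 48 h; on this read-out lower numbers stand for stronger inhibition of growth and higher numbers for weaker inhibition of growth. Compound 1 `COc1ccc(-c2cc(/C=C/C(=O)c3ccc(OC)c(OC)c3)[nH]n2)cc1` gives 1680 nM. Compound 3 `COc1ccc(-c2cc(/C=C/C(=O)c3ccc(N)cc3)[nH]n2)cc1` gives 2010 nM. Compound 2 `COc1cc(-c2cc(/C=C/C(=O)c3ccc(Cl)c(Cl)c3)[nH]n2)cc(OC)c1OC` gives 21400 nM, the highest number of the three; its distance to compound 3, the nearest, and to compound 1, the furthest, both lie beyond the usual scatter of repeated measurements, so compound 2 stands as the weakest inhibitor of growth among the three.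

Compound 4 `COc1ccc(C(=O)/C=C/c2cc(-c3cc(OC)c(OC)c(OC)c3)n[nH]2)cc1OC` has not yet been measured. It keeps the core of compound 2 and differs from it in one place: 3,4-dimethoxyphenyl in place of 3,4-dichlorophenyl on a carbonyl carbon. Within the data shown here, no pair of measured compounds differs in exactly this way, so the size of this step cannot be read directly from the data. The ring that enters is, however, the same ring that compound 1 carries on its carbonyl carbon, and compound 1 gives 1680 nM in this assay, the lowest number measured; that is the ground for the expectation. The expected step is a 5.4-fold lower number from compound 2 to compound 4 (0.73 log units; beyond the scatter), a move toward stronger inhibition of growth, beyond the scatter. Compound 4 is estimated to give about 4000 nM in this assay, with a likely range from 1500 nM to 12000 nM.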

Compound 4, concentration for 50% growth inhibition: 1660 nM
Estimate against measurement, compound 4: 2.4-fold (0.38 log units) above; measured number inside the range.
By their numbers in this assay, from the lowest: compounds 4, 1 and 3 (each within the scatter of the next); then compound 2.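

Among these compounds, this is the first direct reading of a change on the carbonyl carbon, since no earlier pair of compounds differed in one place: putting 3,4-dimethoxyphenyl in place of 3,4-dichlorophenyl gives a 13-fold lower number from compound 2 to compound 4 (1.11 log units; beyond the scatter) in this assay. The position is therefore sensitive to what the ring carries, even though both rings are six-membered aromatic rings of carbon only and the rest of the molecule stays the same. What changes in the count is that two chlorine atoms leave, while two oxygen atoms and two more carbon atoms enter, along with hydrogen-bond acceptors that the leaving ring lacks, but nothing measured here explains why the step is so large.

Going by these compounds, it remains open whether both methoxy groups are needed for this step, or whether a ring with one methoxy group, one chlorine or a mix of the two would read the same way. Also open, on these data alone, is how a plain phenyl, a hydroxyl group or a carboxylic acid on that ring would read, and whether the swap keeps its size when a different ring sits elsewhere on the shared core.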